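The source may report more compounds than this note shows. Statements on the series, on what has been measured and on what is new or still open speak of the compounds shown alone.

In a functional assay on CHO cells for antagonist activity at sphingosine 1-phosphate receptor 2 (Homo sapiens), read by fluorescence and calcium flux, with a stated time of 3 min (on this read-out higher numbers stand for weaker inhibition and lower numbers for stronger inhibition), compound 1 `Cc1cc(C#N)nc(NNC(=O)Nc2cc(Cl)nc(Cl)c2)c1` gives only a limit, > 6600 nM. Compound 2 `Cc1cc(NNC(=O)Nc2cc(Cl)nc(Cl)c2)ncc1-c1cn(C)nc1C` likewise gives only a limit in this assay, > 1400 nM. Compound 3 `Cc1cc(NNC(=O)Nc2cc(Cl)nc(Cl)c2)nc(-c2cnn(C)c2)c1` also gives only a limit in this assay, > 2100 nM. The one step shown, a step that the two limits leave unreadable from compound 1 to compound 3, in which 1-methyl-1H-pyrazol-4-yl replaces cyano on an aromatic carbon, cannot be read, since both of its ends are limits, as the limit of > 6600 nM in this assay, at which 1 of the 3 values shown sits, and the limit of > 2100 nM in this assay, at which 1 of the 3 values shown sits, show. Compound 3 thus stands at a limit with no number of its own, and the two other values shown are limits as well.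

Compound 4 `Cc1cc(NNC(=O)Nc2cc(Cl)nc(Cl)c2)nc(C(=O)N(C)C2CC2)c1` differs from compound 3 in one place: cyclopropyl(methyl)carbamoyl in place of 1-methyl-1H-pyrazol-4-yl on an aromatic carbon. No measured step bears directly on this change, and the single step shown has a size the limits leave unreadable; the limit of > 1400 nM in this assay, at which 1 of the 3 values shown sits, adds only a third limit. Given that (the limit of > 1400 nM in this assay, at which 1 of the 3 values shown sits), the limit of > 2100 nM in this assay, at which 1 of the 3 values shown sits, and the limit of > 6600 nM in this assay, at which 1 of the 3 values shown sits, are each a limit, compound 4 is expected to remain weak in this assay, with a fair chance of yet another limit. Compound 4 is estimated at 5000 nM, within 1500 nM to 20000 nM. The expected step that the limit leaves unreadable from compound 3 to compound 4 therefore carries little weight beyond the scatter.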

Compound 4, half-maximal inhibitory concentration: > 20000 nM
Compound 4: no number, only a limit; the forecaster's own chance of this, stated with the estimate: 65%; middle value at least 4.0-fold (0.60 log units) away from the limit.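

In this assay compound 4 gives only a limit, > 20000 nM, and the steps to compound 4 from compound 1 and from compound 3 therefore cannot be read. The compounds shown leave open what number any of them would reach in this assay, and whether the cyano, 1-methyl-1H-pyrazol-4-yl or cyclopropyl(methyl)carbamoyl group makes any difference.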